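Selenium-bearing aminobicycles: growth inhibition working notes

The source may report more compounds than this note shows. Statements on the series, on what has been measured and on what is new or still open speak of the compounds shown alone.

Measured so far in an ADME assay on 184B5 cells (Homo sapiens) for cytotoxicity, read by MTT assay, with a stated time of 72 h; on this read-out lower numbers stand for stronger inhibition of growth and higher numbers for weaker inhibition of growth:
compound 1 `Nc1nc([SeH])nc2ncccc12` gives 31100 nM
compound 2 `CCCCC[Se]c1nc(N)c2cccnc2n1` gives 40200 nM
compound 3 `Nc1nc([SeH])nc2ccccc12` gives 36700 nM

Compound 1 and compound 2 differ by pentyl in place of hydrogen on a selenium. In this assay this gives a 1.3-fold higher number from compound 1 to compound 2 (0.11 log units; within the scatter), so the pentyl group has not shifted the number beyond what repeated runs would give. Compound 3 carries a different core; the difference between the two cores is not broken down here, and the values of compound 1 and compound 3 lie within the scatter of each other, as do those of compound 3 and compound 2.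

Compound 4 `CCCCC[Se]c1nc(N)c2ccccc2n1` is not yet measured in this assay. It differs from compound 3 by pentyl in place of hydrogen on a selenium, the same change as from compound 1 to compound 2, made on the same kind of place. Because a 1.3-fold higher number from compound 1 to compound 2 (0.11 log units; within the scatter) stayed within the scatter, the same change on the core of compound 3 is expected to leave the number close to that of compound 3, an expected step of a 1.2-fold higher number from compound 3 to compound 4 (0.09 log units; within the scatter). For compound 4 the estimate is 45000 nM, with a range from 24000 nM to 85000 nM.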

Compound 4, concentration for total growth inhibition: 43600 nM
Estimate against measurement, compound 4: 1.0-fold (0.01 log units) above, and the stated range covers the measured number.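

In this assay, pentyl in place of hydrogen on a selenium on the core of compound 3 gives a small step (a 1.2-fold higher number from compound 3 to compound 4 (0.07 log units; within the scatter)), and the change reads alike on the two cores: the same change on two cores in this assay, a 1.3-fold higher number (0.11 log units; within the scatter) from compound 1 to compound 2 and a 1.2-fold higher number (0.07 log units; within the scatter) from compound 3 to compound 4, 1.1-fold (0.04 log units) apart, within the scatter of two such steps

Carried from the core of compound 1 to the core of compound 3, the change therefore stays within the scatter on both, and the two steps cannot be told apart. This is agreement between two steps that are both too small to read as an effect, so it shows that pentyl leaves the number in place on these two cores, not that a real shift is being transferred from one core to the other. Two cores and one group also say nothing about other cores or about other read-outs.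

Still open, as far as these compounds go, is whether a shorter chain such as methyl, a longer chain such as octyl, or a chain ending in an amine or a carboxylic acid would move the number beyond the scatter on either core. Also open, from the compounds shown here alone, is what sulfur in place of selenium would do on these cores.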